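Swapping methylsulfonyl for methoxy on a glycine transporter inhibitor

The compounds below may be only part of what the source reports. "The series", "measured", "known", "first", "only" and "open" are said of these compounds alone.

The series rests on three measured compounds. Compound 1 `CN(CCC(Oc1ccc(S(C)(=O)=O)cc1)c1ccccc1)CC(=O)O` gives 100000 nM in an assay on CHO cells for inhibition of sodium- and chloride-dependent glycine transporter 1 (Homo sapiens); a higher number here means a weaker inhibitor, a lower number a stronger inhibitor. Compound 2 `CN(CCCC(=O)O)CCC(Oc1ccc(C(F)(F)F)cc1)c1ccccc1` gives 100000 nM in this assay, so compound 1 and compound 2 sit level at the digits reported, and together they hold the highest numbers of the three. Compound 3 `CN(CCC(Cc1ccc(C(F)(F)F)cc1)c1ccccc1)CC(=O)O`, with a trifluoromethyl group and a carbon link in place of the ether oxygen, gives 1000 nM in this assay, a number lower than that of compound 1 and well beyond the scatter.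

Compound 4 `COc1ccc(OC(CCN(C)CC(=O)O)c2ccccc2)cc1` has not yet been measured in this assay. It differs from compound 1 in a single place: methoxy in place of methylsulfonyl on an aromatic carbon. Going by the values given here, no measured pair isolates this change, so the direction is open. Because compound 1 gives 100000 nM, there is ample room for the number to fall. For compound 4 the account expects a step of a 10-fold lower number from compound 1 to compound 4 (1.00 log units; beyond the scatter), toward a lower number. The estimate for compound 4 is 10000 nM, within 1000 nM to 100000 nM.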

Compound 4, half-maximal inhibitory concentration: 3980 nM
For compound 4 the middle estimate is 2.5-fold (0.40 log units) above the measured one; the measured number falls inside the stated range.
By their numbers in this assay, from the lowest: compound 3; then compound 4; then compounds 1 and 2 (each within the scatter of the next).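

In this assay, the aromatic carbon para to a large group turns out to be sensitive to what it carries: methoxy in place of methylsulfonyl brings a 25-fold lower number from compound 1 to compound 4 (1.40 log units; beyond the scatter). Going by these compounds alone, this is the first step that isolates a single place, and it gives this position a direction that the earlier compounds could not show. Methoxy has fewer heavy atoms and hydrogen-bond acceptors than methylsulfonyl, but nothing measured here explains the shift.

A single pair cannot show whether the lower number depends on methoxy itself or would also follow with a chlorine, a hydroxyl or an ethoxy on this carbon. It also leaves open whether the step would hold with an amide in place of the carboxylic acid.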